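Ester for benzyl ether on the amide-flanking chain

The source may report more compounds than this note shows. Statements on the series, on what has been measured and on what is new or still open speak of the compounds shown alone.

Three compounds have numbers in an assay on isolated protein for inhibition of cathepsin S (Homo sapiens); a lower number here means a stronger inhibitor, a higher number a weaker inhibitor. Compound 1 `Cc1cccc(C(=O)N[C@@H](CC(C)C)C(=O)NCCN2CCc3cc(Cl)ccc32)c1` gives 196 nM. Compound 2 `COc1cccc(C(=O)N[C@@H](CCC2CCCCC2)C(=O)N[C@@H](COCc2ccccc2)CN2CCc3cc(F)ccc32)c1` gives 23 nM, the second highest of the three numbers. Compound 3 `COc1cccc(C(=O)N[C@@H](CC(C)(C)C)C(=O)N[C@@H](CC(=O)O)CN2CCc3cc(F)ccc32)c1` gives 6 nM; of the three, compound 3 stands nearest to compound 2 and compound 1 furthest from it. Among the measured compounds shown here, no two measured compounds differ in a single place, so no isolated step is known within the set. Compound 4 `CCOC(=O)C[C@@H](CN1CCc2cc(F)ccc21)NC(=O)[C@H](CCC1CCCCC1)NC(=O)c1cccc(OC)c1` is not yet measured. It differs from compound 2 by ethoxycarbonyl in place of benzyloxy on a saturated chain carbon, two bonds along the chain from an amide-type nitrogen. Without a measured pair isolating this change, the direction is not fixed; the expected step is a 1.1-fold higher number from compound 2 to compound 4 (0.04 log units; within the scatter), none beyond the scatter. For compound 4 the estimate in this assay is 25 nM, within 7 nM to 90 nM.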

Compound 4, inhibition constant: 16 nM
Estimate against measurement, compound 4: 1.6-fold (0.19 log units) above; measured number inside the range.
By their numbers in this assay, from the lowest: compound 3; then compounds 4 and 2 (each within the scatter of the next); then compound 1.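

The step in this assay reads a 1.4-fold lower number from compound 2 to compound 4 (0.16 log units; within the scatter). Among the compounds shown here, this is the first isolated change in the set, and it shows that this chain carbon tolerates ethoxycarbonyl in place of benzyloxy, with the aromatic ring removed and fewer heavy atoms, while the number stays level. No measurement on hand accounts for the two groups reading alike.

Compounds 1 and 3 differ from compound 4 in more than one place, so steps to them cannot be read. On these data alone, how a primary amide or an amine at this position would read, with the rest of compound 4 unchanged, remains open.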